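Fluoro for Methyl on the Aryl Ring: Compound 4

A few compounds are considered here, and "the series" means these few. Any claim that something is new, unique, unknown or untested is made for them only; others in the source may bear on it.

Measured compounds:
- Compound 1, `Cc1ccc(C2=NO[C@@H]3[C@H](CO)C[C@H](CO)[C@H]23)cc1`: in a functional assay on PC-3 cells (Homo sapiens) for cytotoxicity, read by MTT assay, with a stated time of 48 h (on this read-out higher numbers stand for weaker inhibition and lower numbers for stronger inhibition), compound 1 gives 28 ug/mL.
- Compound 2, `COc1ccc(C2=NO[C@@H]3[C@H](CO)C[C@H](CO)[C@H]23)cc1OC`: compound 2 reaches only the assay limit of > 50 ug/mL.
- Compound 3, `OC[C@@H]1C[C@H](CO)[C@@H]2C(c3ccc4ccccc4c3)=NO[C@H]12`: compound 3 gives 48.4 ug/mL.

Three compounds share one core and differ only in the aromatic group attached to it. For the measured compounds named here, compound 1 and compound 3 are the only two that yield real numbers, and those two numbers sit within the usual scatter of each other, so neither can be told apart from the other on this read-out. Compound 2 gives no number at all, only a limit, as shown by the limit of > 50 ug/mL in this assay, at which 1 of the 3 values shown sits.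

Compound 4, `OC[C@@H]1C[C@H](CO)[C@@H]2C(c3ccc(F)cc3)=NO[C@H]12`, is the next compound to be measured. It differs from compound 1 by a single substitution: fluoro in place of methyl on an aromatic carbon. Going by the values given here, no measured pair in this set makes exactly that exchange, so there is no step to lean on. A change of one heavy atom for another of the same size, with no gain or loss of donors or acceptors, is expected to move the number little, and most likely not beyond the scatter in either direction.

The estimated step from compound 1 to compound 4 is a 1.1-fold higher number from compound 1 to compound 4 (0.06 log units; within the scatter). Compound 4 is therefore expected to give about 32 ug/mL, in a range from 16 ug/mL to 60 ug/mL.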

Compound 4, half-maximal inhibitory concentration: > 50 ug/mL
Compound 4: only a limit was reported (the forecaster's own chance of this, stated with the estimate: 25%); at least 1.5-fold (0.19 log units) between middle value and limit.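

In this assay, compound 4 gives > 50 ug/mL, which is a limit of the assay and not a number. Exchanging methyl for fluoro on the aromatic carbon para to a large group gives an at least 1.7-fold higher number from compound 1 to compound 4 (0.25 log units; that floor lies within the scatter), so this single exchange on compound 1 does not leave a readable value, but the smallest change it allows cannot be told apart from ordinary repeat variation. This is the first direct comparison at this position, and it adds a second compound to those that give no number, which leaves fewer values for comparing the aromatic groups: the limit of > 50 ug/mL in this assay, at which 2 of the 4 values shown sit.

As far as these compounds go, the size of the change remains open, as the result fits both a small shift that just crosses the limit and a much larger loss of inhibition, and no true value for compound 4 can be read from it. Also open, from the compounds shown here alone, is how this assay would respond to an amine, a carboxylic acid, a chloro group or a longer chain such as propyl on the same aromatic carbon, and whether any of these would give a number clearly apart from that of compound 1.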